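Swapping a halogenated ring on a shared core

This account rests on a few compounds, and the source may have more. Where it says the series, first, only, none or still open, it means among the compounds named here.

Three compounds with a shared core have been examined in a functional assay on MCF7 cells (Homo sapiens) for cytotoxicity, read by CCK-8 assay, with a stated time of 72 h; on this read-out lower numbers stand for stronger inhibition and higher numbers for weaker inhibition. Compound 1, with the structure `COc1ccccc1/C=c1\c(=O)[nH]/c(=C/c2ccccc2Cl)c(=O)n1C`, gives 200 nM. Compound 2, with the structure `C=CCn1c(=O)/c(=C\c2cccc(Br)c2)[nH]c(=O)/c1=C\c1ccccc1OC`, gives 5400 nM in this assay. Compound 3, with the structure `C=CCn1c(=O)/c(=C\c2cc(OC)c(OC)c(OC)c2)[nH]c(=O)/c1=C\c1cccc(Br)c1`, is reported in this assay as "not active" (no number reported), so no number stands for it. Among the two numbers at hand, compound 2 holds the highest, and its nearest neighbour is compound 1, which lies well below it, beyond the usual scatter of repeated measurements.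

Compound 4, with the structure `C=CCn1c(=O)/c(=C\c2cccc(Cl)c2Cl)[nH]c(=O)/c1=C\c1ccccc1OC`, has not yet been measured in this assay. It differs from compound 2 in one place: 2,3-dichlorophenyl in place of 3-bromophenyl on a double-bonded chain carbon bound to an aromatic carbon. Among the measured compounds shown here, no measured pair in this set shows exactly this change, so its size cannot be read from the data. The expectation is a modest shift downward, meaning somewhat stronger inhibition, while staying closer to compound 2 than to compound 1, with real doubt about whether it clears the scatter at all. The estimated step from compound 2 to compound 4 is a 2.7-fold lower number from compound 2 to compound 4 (0.43 log units; beyond the scatter) in this assay. For compound 4 the estimate in this assay is 2000 nM, with a plausible range from 400 nM to 10000 nM.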

Compound 4, half-maximal inhibitory concentration: 2100 nM
Beside the measured number, compound 4's estimate is 1.1-fold (0.02 log units) below it, and the stated range covers the measured number.
By their numbers in this assay, from the lowest: compound 1; then compound 4; then compound 2.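

In this assay, the change at this position gives a 2.6-fold lower number from compound 2 to compound 4 (0.41 log units; beyond the scatter) when 2,3-dichlorophenyl takes the place of 3-bromophenyl on a double-bonded chain carbon bound to an aromatic carbon. Among the compounds shown here, this is the first step in the set in which only one place differs, and it shows that the number responds to this swap, though modestly, and that a measurable number survives with two chlorine atoms on the ring instead of one bromine atom. The data offer no measurement that accounts for this shift.

Because the swap changes both the kind of halogen and the number of halogens, these compounds cannot show which of the two matters, and 3-chlorophenyl at the same place would separate them. Also open, going by these compounds, are how this place responds to a ring carrying an amine or a carboxylic acid instead of a halogen, and whether the same swap would bring a similar step on the core of compound 1.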